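Methoxy added to the phenyl ring of compound 2

This account rests on a few compounds, and the source may have more. Where it says the series, first, only, none or still open, it means among the compounds named here.

Compound 1 `CCC[C@H](Nc1cncc(-c2ccc(O)c(OC)c2)n1)c1ccccc1` and compound 2 `CCCC(Nc1cncc(-c2ccc(O)c(OC)c2)n1)c1ccccc1` share one core and differ only in how one centre is drawn. In a functional assay on DU-145 cells (Homo sapiens) for cytotoxicity, read by MTT assay, with a stated time of 72 h (on this read-out higher numbers stand for weaker inhibition and lower numbers for stronger inhibition), compound 1 gives 200 nM, and compound 2 gives 500 nM. The step of a 2.5-fold higher number from compound 1 to compound 2 (0.40 log units; beyond the scatter) is the only measured one in the set; the sole difference behind it is the fact that one of compounds 1 and 2 is drawn with a defined configuration and the other without, at the place where they differ. Compound 2 thus holds the highest of the two numbers, its nearest neighbour being compound 1.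

Compound 3 `CCCC(Nc1cncc(-c2ccc(O)c(OC)c2)n1)c1ccc(OC)cc1` is not yet measured. It differs from compound 2 by methoxy in place of hydrogen on an aromatic carbon, para to a large group. Among the compounds with values here, no measured step touches this ring or this kind of change; the step from compound 1 to compound 2 concerns only a drawn configuration and says nothing about substitution on the phenyl ring. The expected step of no change at the digits printed from compound 2 to compound 3 (within the scatter) is therefore none beyond the scatter, in either direction. Compound 3 is estimated at 500 nM in this assay, between 150 nM and 1700 nM, the width reflecting the absence of any guiding step.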

Compound 3, half-maximal inhibitory concentration: 3000 nM
Beside the measured number, compound 3's estimate is 6.0-fold (0.78 log units) below it; the whole stated range lies below it.
By their numbers in this assay, from the lowest: compound 1; then compound 2; then compound 3.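

In this assay, the phenyl ring of compound 2 turns out to be sensitive to substitution: exchanging phenyl for 4-methoxyphenyl gives a 6.0-fold higher number from compound 2 to compound 3 (0.78 log units; beyond the scatter). Within the data shown here, this is the first reading on this ring; the earlier pair differs only in a drawn configuration at the saturated chain carbon, so it gave no information about aromatic substitution, whereas this pair shows that methoxy on an aromatic carbon, para to a large group, costs activity on this read-out. Nothing measured in the series speaks to the reason for this loss.

As far as these compounds go, whether the loss belongs to methoxy itself or would follow any group at this place stays open, and a fluorine, a hydroxyl or an ethoxy on the same ring carbon would help separate those readings, as would methoxy at other carbons of the ring. Also open, from the compounds shown here alone, is whether a defined configuration at the chain carbon would shift the number for the 4-methoxyphenyl compound as it does in a 2.5-fold higher number from compound 1 to compound 2 (0.40 log units; beyond the scatter), read in the opposite direction.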